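A few compounds are considered here, and "the series" means these few. Any claim that something is new, unique, unknown or untested is made for them only; others in the source may bear on it.

Compound 1 `NS(=O)(=O)N1CCC(C(=O)/C(=N/O)Nc2ccc(F)c(Br)c2)CC1` gives 45 nM in an assay on tissue (HeLa cells) for inhibition of Indoleamine 2,3-dioxygenase 1 (Homo sapiens), with a stated time of 48 h; on this read-out higher numbers stand for weaker inhibition and lower numbers for stronger inhibition.
Compound 2 `O=C(Nc1ccccc1)[C@H]1CC[C@H](C(=O)/C(=N/O)Nc2ccc(F)c(Br)c2)CC1` gives 197 nM in this assay.
Compound 3 `O=C(/C(=N/O)Nc1ccc(F)c(Br)c1)C1CCN(S(=O)(=O)NCc2ccccc2)CC1` gives 262 nM in this assay.

Among these three, compound 1 has the lowest number, and both other compounds lie beyond the scatter above it. Compound 4 `O=C(/C(=N/O)Nc1ccc(F)c(Br)c1)C1CCN(C(=O)c2ccccc2)CC1` differs from compound 1 by benzoyl in place of sulfamoyl on an amine nitrogen in a ring. Among the measured compounds shown here, one measured step touches this place: a 5.8-fold higher number from compound 1 to compound 3 (0.77 log units; beyond the scatter), where a group was added on the sulfonamide nitrogen while the sulfamoyl group itself stayed. For the measured compounds named here, compound 2, which carries no sulfamoyl group, also sits above compound 1, though no single step connects the two. Replacing the sulfamoyl group altogether is therefore expected to raise the number by a modest step, a 6.7-fold higher number from compound 1 to compound 4 (0.82 log units; beyond the scatter). Compound 4 is expected to give about 300 nM, within a range from 80 nM to 1200 nM.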

Compound 4, half-maximal inhibitory concentration: 281 nM
Compound 4: middle estimate off by 1.1-fold (0.03 log units), on the high side; the measured number falls inside the stated range.
By their numbers in this assay, from the lowest: compound 1; then compounds 2, 3 and 4 (each within the scatter of the next).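

Replacing the sulfamoyl group altogether with benzoyl on the ring amine nitrogen raises the number by a modest step (a 6.2-fold higher number from compound 1 to compound 4 (0.80 log units; beyond the scatter)), so this benzoyl group does not match the unsubstituted sulfamoyl group of compound 1. Compound 3 (262 nM) and compound 4 (281 nM) lie within the scatter of each other, so a benzyl-bearing sulfamoyl group and a benzoyl group read alike here. No measurement shown explains this step. Going by these compounds, whether a smaller acetyl or methanesulfonyl group on that nitrogen, or the free amine, would keep the low number of compound 1 remains open.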